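This account rests on a few compounds, and the source may have more. Where it says the series, first, only, none or still open, it means among the compounds named here.

Compound 3 `CC(C)(C)n1ncc(OCc2nnc(-c3ccc(Cl)cc3)o2)c(Cl)c1=O` gives 1.9 ug/mL in a functional assay on the whole organism for inhibition, with Mythimna separata as the target, with a stated time of 5 days (a higher number here means that more compound is needed for the effect, a lower number that less compound is needed), the lowest of the two numbers shown. Compound 2 `CC(C)(C)n1ncc(OCc2nnc(-c3cc(F)c(F)cc3F)o2)c(Cl)c1=O` gives 75.7 ug/mL in this assay. Compound 1 `Cc1nnc(COc2cnn(C(C)(C)C)c(=O)c2Cl)o1` gives only a limit in this assay, namely > 300 ug/mL. The change to compound 4 `CC(C)(C)n1ncc(OCc2nnc(-c3c(F)cccc3F)o2)c(Cl)c1=O` is 2,6-difluorophenyl in place of 4-chlorophenyl on an aromatic carbon. Three measured steps exchange groups at that same position: an at least 3.9-fold lower number from compound 1 to compound 2 (0.59 log units; beyond the scatter), an at least 150-fold lower number from compound 1 to compound 3 (2.19 log units; beyond the scatter) and a 40-fold lower number from compound 2 to compound 3 (1.60 log units; beyond the scatter). Because the step of a 40-fold lower number from compound 2 to compound 3 (1.60 log units; beyond the scatter) shows a fluorinated phenyl giving a clearly higher number than 4-chlorophenyl, a rise beyond the scatter is expected here too, though the two fluorinated groups are not identical, so the size is uncertain. The expected step is a 16-fold higher number from compound 3 to compound 4 (1.20 log units; beyond the scatter). Compound 4 is estimated at 30 ug/mL, with a range from 5 ug/mL to 150 ug/mL.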

Compound 4, half-maximal effective concentration: 45.4 ug/mL
Compound 4: middle estimate off by 1.5-fold (0.18 log units), on the low side; the measured number falls inside the stated range.
By their numbers in this assay, from the lowest: compound 3; then compounds 4 and 2 (each within the scatter of the next). At a limit, above all of these: compound 1.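

In this assay, 2,6-difluorophenyl also gives a much higher number than 4-chlorophenyl, with a 24-fold higher number from compound 3 to compound 4 (1.38 log units; beyond the scatter). Two differently fluorinated phenyl groups now read alike, with a 1.7-fold lower number from compound 2 to compound 4 (0.22 log units; within the scatter), and neither matches compound 3. The fluorinated group still gives a lower number than methyl, with an at least 6.6-fold lower number from compound 1 to compound 4 (0.82 log units; beyond the scatter), a step that rests on a limit: the limit of > 300 ug/mL in this assay, at which 1 of the 4 values shown sits.

On these data alone, it remains open whether the low number of compound 3 depends on the chlorine itself or on its place on the phenyl ring, and how unsubstituted phenyl, 4-bromophenyl or 4-methoxyphenyl would compare.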